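Benzyloxy in place of trifluoromethyl in compound 1

The source may hold more compounds than are shown below. What is called first, only, known or untested is meant among the compounds shown, and "the series" means these compounds.

For the measured compounds named here, in an ADME assay on microsomes (Mus musculus) for metabolic stability (on this read-out lower numbers stand for slow clearance and higher numbers for fast clearance), compound 1 (`CNC(=O)[C@@H]1CCCN1S(=O)(=O)c1ccc(Cl)c(COc2cccc3c(C(F)(F)F)cc(C)nc23)c1Cl`) gives 1380 mL/min/kg, the lower of the two numbers measured so far. Going by the values given here, the only other measured compound, compound 2 (`Cc1cc(C(F)(F)F)c2cccc(OCc3c(Cl)ccc(S(=O)(=O)N4CCC[C@H]4C(N)=O)c3Cl)c2n1`), gives 12600 mL/min/kg. Compound 3 (`CNC(=O)[C@@H]1CCCN1S(=O)(=O)c1ccc(Cl)c(COc2cccc3c(OCc4ccccc4)cc(C)nc23)c1Cl`) keeps the rest of compound 1 but carries benzyloxy in place of trifluoromethyl on an aromatic carbon, opposite the ring nitrogen: benzyloxy in place of trifluoromethyl on an aromatic carbon.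

Among the compounds with values here, the one measured step is a 9.1-fold higher number from compound 1 to compound 2 (0.96 log units; beyond the scatter), for hydrogen in place of methyl on an amide-type nitrogen. That change lies at another place in the molecule, and no measured change touches this aromatic carbon. The step therefore bears only loosely, as a sign of how far this assay can move within this small set. Compound 1 holds the low end at 1380 mL/min/kg, so a rise is expected rather than a fall, though with little support. The expected change is a 2.0-fold higher number from compound 1 to compound 3 (0.31 log units; beyond the scatter), which is smaller than the measured step. Compound 3 is estimated at 2800 mL/min/kg, with an expected range from 900 mL/min/kg to 8000 mL/min/kg.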

Compound 3, clearance: 1820 mL/min/kg
Beside the measured number, compound 3's estimate is 1.5-fold (0.19 log units) above it, and the stated range covers the measured number.
By their numbers in this assay, from the lowest: compounds 1 and 3 (each within the scatter of the next); then compound 2.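

In this assay, the aromatic carbon opposite the ring nitrogen had not been varied before, and the exchange of trifluoromethyl for benzyloxy there gives a 1.3-fold higher number from compound 1 to compound 3 (0.12 log units; within the scatter). Benzyloxy brings one six-membered aromatic ring of carbon only and 1 hydrogen-bond acceptor, neither of which trifluoromethyl has, yet the read-out stays within the scatter, whereas the change on the amide-type nitrogen gives a 9.1-fold higher number from compound 1 to compound 2 (0.96 log units; beyond the scatter). The data offer no measured basis for explaining why this exchange at the aromatic carbon leaves the clearance number within the scatter.

As far as these compounds go, whether an amine, a carboxylic acid or a shorter ether such as methoxy on this aromatic carbon would also stay within the scatter of compound 1 remains open, since a single exchange says little about the range of groups this position accepts. Also open, from the compounds shown here alone, is whether benzyloxy would behave the same way with hydrogen in place of methyl on the amide-type nitrogen, the setting of compound 2, which gives 12600 mL/min/kg in this assay.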